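The source may hold more compounds than are shown below. What is called first, only, known or untested is meant among the compounds shown, and "the series" means these compounds.

In a toxicity assay on NIH3T3 cells (Mus musculus) for cytotoxicity, read by resazurin assay (on this read-out lower numbers stand for an effect already at smaller amounts and higher numbers for an effect only at larger amounts of compound), compound 1 (`COC(=O)c1ccc(NCc2cncn2Cc2ccc(Cl)cc2)cc1-c1ccccc1`) gives 25000 nM and compound 2 (`COC(=O)c1ccc(NCc2cncn2Cc2ccccc2Cl)cc1-c1ccccc1`) gives 10000 nM. Among the compounds with values here, for compound 3 (`COC(=O)c1ccc(NCc2cncn2Cc2ccccc2F)cc1-c1ccccc1`) the result reads "not determined" (no result reported), so it has no place on this scale and no step from it can be sized. Compound 4 (`COC(=O)c1ccc(NCc2cncn2Cc2ccc(Br)cc2)cc1-c1ccccc1`) differs from compound 3 by 4-bromophenyl in place of 2-fluorophenyl on a saturated chain carbon bound to an aromatic nitrogen. Within the data shown here, the one measured step that bears on this change is a 2.5-fold lower number from compound 1 to compound 2 (0.40 log units; beyond the scatter), modest in size, with 2-chlorophenyl in place of 4-chlorophenyl. Compound 4 carries 4-bromophenyl, so the nearest reference is the 4-chlorophenyl of compound 1 at 25000 nM. A value in that region of this assay is expected, with no shift beyond the scatter. For compound 4 the estimated value is 20000 nM, with an expected range of 8000 nM to 50000 nM.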

Compound 4, half-maximal effective concentration: > 10000 nM
Compound 4: no number, only a limit (the forecaster's own chance of this, stated with the estimate: 20%); the middle value lies beyond the limit too.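

In this assay compound 4 gives only a limit, > 10000 nM, and not a number: the limit of > 10000 nM in this assay, at which 1 of the 4 values shown sits. With 4-bromophenyl on a saturated chain carbon bound to an aromatic nitrogen, the series shows a number no lower from compound 2 to compound 4 (the limit leaves the size open), so this change to the 2-chlorophenyl compound does not bring the reading down. The step between compound 1 and compound 4, bromo in place of chloro on an aromatic carbon, cannot be read.

Going by these compounds, whether bromo and chloro on the phenyl ring differ at all remains open. So does how a carboxylic acid or an amine on that ring, or a longer chain in place of the benzyl group, would read in this assay.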